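A Chlorine Added to a Series Without Measurable Potency

A few compounds are considered here, and "the series" means these few. Any claim that something is new, unique, unknown or untested is made for them only; others in the source may bear on it.

Compound 1, `Cc1nnc(SCc2ccccc2)n1N1C(=O)c2ccccc2C1=O`: in a functional assay on MKN-45 cells (Homo sapiens) for cytotoxicity, read by MTT assay, with a stated time of 48 h (a lower number here means a stronger inhibitor, a higher number a weaker inhibitor), compound 1 gives > 200000 nM, which is a limit of the assay rather than a number.
Compound 2, `CCc1nnc(SCc2ccccc2)n1N1C(=O)c2ccccc2C1=O`: compound 2 gives > 200000 nM, again a limit.
Compound 3, `CCCc1nnc(SCc2ccccc2)n1N1C(=O)c2ccccc2C1=O`: compound 3 gives > 200000 nM, also a limit.

Compound 3 therefore stands nowhere distinct on the numbers shown: every measured value of the series sits at the limit of > 200000 nM in this assay, at which 3 of the 3 values shown sit, and nothing says whether compound 3 is weaker or stronger than its two relatives. The three steps within the series, a step that the two limits leave unreadable from compound 1 to compound 2, a step that the two limits leave unreadable from compound 1 to compound 3 and a step that the two limits leave unreadable from compound 2 to compound 3, are all unreadable for the same reason, since both ends of each step are limits.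

Compound 4, `CCCc1nnc(SCc2ccccc2Cl)n1N1C(=O)c2ccccc2C1=O`, differs from compound 3 by chloro in place of hydrogen on an aromatic carbon. Among the compounds with values here, no measured step bears on a change of this kind, and the steps that exist give no size at all. The expectation for the step from compound 3 to compound 4, a number no higher from compound 3 to compound 4 (the limit leaves the size open), is therefore no readable change beyond the scatter, with the most likely outcome being another limit. For compound 4 the estimated value is 200000 nM, with a range from 60000 nM to 600000 nM.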

Compound 4, half-maximal inhibitory concentration: > 200000 nM
Compound 4 gave a limit, no number; the forecaster's own chance of this, stated with the estimate: 85%; the middle value sits exactly at the limit.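

In this assay compound 4 gives > 200000 nM as a limit, not a number. Compound 3 also sits at a limit, so no size can be read for the chloro change between compound 3 and compound 4. The compounds shown leave open how potent any of them is, and whether any of these changes alters potency, since all share one limit: the limit of > 200000 nM in this assay, at which 4 of the 4 values shown sit.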